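A few compounds are considered here, and "the series" means these few. Any claim that something is new, unique, unknown or untested is made for them only; others in the source may bear on it.

Measured so far:
- compound 1 `O=C(N/N=C/c1ccccc1)c1cnccn1`: 75%
- compound 2 `O=C(N/N=C/c1ccccc1Cl)c1cnccn1`: 66%

In an ADME assay on J774 cells (Mus musculus) for cytotoxicity, read by MTT assay, with a stated time of 48 h, tested at 100 ug/mL (on this read-out lower numbers stand for a stronger effect and higher numbers for a weaker effect at the one concentration tested), compound 1 gives 75% and compound 2 gives 66%. Compound 2 carries the smaller of the two numbers shown, but the only step in the set, a number 9 percentage points lower from compound 1 to compound 2 (within the scatter), lies within the scatter, so the two compounds cannot be separated on this read-out.

Compound 3 `O=C(N/N=C/c1ccccc1F)c1cnccn1` follows from compound 2 by fluoro in place of chloro on an aromatic carbon. Among the measured compounds shown here, no measured step shows one halogen replaced by another at this position; the single step on record, chloro in place of hydrogen on an aromatic carbon, is a number 9 percentage points lower from compound 1 to compound 2 (within the scatter) and stayed within the scatter. The exchange of one small substituent for another at the same place is, if anything, a smaller change than adding chloro where hydrogen stood, so no step beyond the scatter in this assay is expected in either direction.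

For compound 3 the expected value in this assay is 70%, between 55% and 85%, which amounts to an expected step of a number 4 percentage points higher from compound 2 to compound 3 (within the scatter).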

Compound 3, a percentage reported as activity, at one concentration (the size of the read-out at that concentration, not a potency): 100%
For compound 3 the middle estimate is 30 percentage points below the measured one, and the stated range ends below it.
By their numbers in this assay, from the lowest: compounds 2 and 1 (each within the scatter of the next); then compound 3.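

In this assay, this place on the aromatic ring, ortho to a large group, responds to the choice of halogen: a number 34 percentage points higher from compound 2 to compound 3 (beyond the scatter), whereas chloro in place of hydrogen gave only a number 9 percentage points lower from compound 1 to compound 2 (within the scatter). Fluoro in place of hydrogen also moves the number, a number 25 percentage points higher from compound 1 to compound 3 (beyond the scatter), so compound 3 has the weakest effect of the three at the one concentration tested, and the two halogens cannot be treated as interchangeable at this place. Nothing at hand bears on why fluoro and chloro part here.

The three compounds leave open whether the shift belongs to fluoro alone or would also appear with bromo, methoxy, an amine or a carboxylic acid at this same place, and whether fluoro elsewhere on the ring would act in the same way. With one concentration per compound, the reading for compound 3 of 100% also leaves open how the series would separate at higher concentrations or as full concentration-response curves.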